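Swapping a nitrile for a methyl on a weak urea

The compounds below may be only part of what the source reports. "The series", "measured", "known", "first", "only" and "open" are said of these compounds alone.

Measured compounds:
compound 1, `CCCCCCCCCNC(=O)N(Cc1cc(OC)ccc1OC)n1cnnc1`: > 50000 nM
compound 2, `COc1ccc(CN(C(=O)Nc2ccc(C#N)cc2)n2cnnc2)cc1OC`: > 50000 nM
compound 3, `O=C(Nc1ccccc1)N(Cc1ccccn1)n1cnnc1`: 24900 nM

In a functional assay on A549 cells (Homo sapiens) for cytotoxicity, read by MTT assay, with a stated time of 48 h (a higher number here means a weaker inhibitor, a lower number a stronger inhibitor), compound 2 reaches only the limit of the assay, reported as > 50000 nM. Compound 1 likewise gives only a limit, > 50000 nM. For the measured compounds named here, compound 3 is the one compound with a number, 24900 nM. Two of the three values therefore sit at the same limit (the limit of > 50000 nM in this assay, at which 2 of the 3 values shown sit), and compound 2 is one of them: its cytotoxicity toward these cells is too weak to be measured as a number, and nothing in the data sets it apart from compound 1.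

Compound 4, `COc1ccc(CN(C(=O)Nc2ccc(C)cc2)n2cnnc2)cc1OC`, keeps the whole of compound 2 except one substituent: methyl in place of cyano on an aromatic carbon. Going by the values given here, no pair of measured compounds shows a step of this kind, so the size of its effect in this assay has to be guessed. With so little room for a compound already at the limit to get weaker, and no reason in the data to expect a sharp gain, the change is expected to stay within the scatter. The expected step that the limit leaves unreadable from compound 2 to compound 4 is thus essentially none. Compound 4 is estimated to give 60000 nM, between 20000 nM and 200000 nM, most likely again reported only as a limit.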

Compound 4, half-maximal inhibitory concentration: 22200 nM
Beside the measured number, compound 4's estimate is 2.7-fold (0.43 log units) above it; the range from low to high includes it.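

Changing 4-cyanophenyl to 4-methylphenyl brings a compound off the limit in this assay, giving an at least 2.2-fold lower number from compound 2 to compound 4 (0.35 log units; beyond the scatter). This shows that the aromatic position is not silent: a single small substituent there separates a compound with a measured number from one without. The full size of the step cannot be read, because compound 2 gives only a limit and not a number: the limit of > 50000 nM in this assay, at which 2 of the 4 values shown sit.

Whether the difference comes from gaining the methyl or from losing the nitrile stays open, as only these two groups are shown at this position on this core. A chlorine atom, a methoxy group or an amine in the same place would show whether the number follows the substituent more widely or is particular to this one pair.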